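Swapping nitro for methoxy on the aromatic ring

The source may report more compounds than this note shows. Statements on the series, on what has been measured and on what is new or still open speak of the compounds shown alone.

Compound 1 `COc1cc(C(=O)/C=C\Nc2ccc(-c3nc4cc(OC)c(OC)c(OC)c4s3)cc2)c(Br)c(OC)c1OC` gives 15600 nM
Compound 2 `COc1cc(C(=O)/C=C\Nc2ccc(-c3nc4cc(OC)c(OC)c(OC)c4s3)cc2)cc([N+](=O)[O-])c1OC` gives 9800 nM

Both compounds were measured in a functional assay on MDA-MB-231 cells (Homo sapiens) for antiproliferative activity, read by sulforhodamine B assay, with a stated time of 48 h; a lower number here means a stronger inhibitor, a higher number a weaker inhibitor. Compound 2, at 9800 nM, has the lowest of the two numbers, but the only other reference point is compound 1 at 15600 nM, and the two values lie within the usual scatter of each other. The data therefore do not separate them, and compound 2 can only be placed level with compound 1.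

The next compound is compound 3 `COc1cc(C(=O)/C=C\Nc2ccc(-c3nc4cc(OC)c(OC)c(OC)c4s3)cc2)cc(OC)c1OC`, which keeps the shared core of compound 2 and carries methoxy in place of nitro on an aromatic carbon, ortho to a methoxy group and meta to a large group: methoxy in place of nitro on an aromatic carbon. Among the measured compounds shown here, no measured step shows what such a swap does in this assay, so the expectation is broad and rests on the two values alone. Only a small shift toward a lower number is expected, with nothing beyond the scatter, as the estimated step of a 1.5-fold lower number from compound 2 to compound 3 (0.18 log units; within the scatter) shows. For compound 3 the expected value is 6500 nM, with a range from 1500 nM to 20000 nM.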

Compound 3, half-maximal inhibitory concentration: 16500 nM
Estimate against measurement, compound 3: 2.5-fold (0.40 log units) below; low and high end bracket the measured number.
By their numbers in this assay, from the lowest: compounds 2, 1 and 3 (each within the scatter of the next).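

In this assay, methoxy in place of nitro on this aromatic carbon gives a 1.7-fold higher number from compound 2 to compound 3 (0.23 log units; within the scatter), so the assay does not tell these two groups apart at this place, although they differ in heavy atoms and hydrogen-bond acceptors. Compound 3 also provides a second comparison in one place, hydrogen in place of bromo on an aromatic carbon, which gives a 1.1-fold higher number from compound 1 to compound 3 (0.02 log units; within the scatter). Neither change therefore moves the number beyond the scatter, and among these three compounds no substituent stands out from the others; nothing available here offers an explanation of these results.

Going by these compounds, what remains open is whether a group of another kind on this aromatic carbon, such as an amine or a carboxylic acid, would give a step from compound 3 that lies beyond the scatter. The same question stands for the aromatic carbon that carries bromo in compound 1, where chloro or a longer chain such as ethoxy could be compared with the hydrogen of compound 3.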